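Cytotoxicity notes: aryl to cyclohexylmethyl on the fused core

The compounds below may be only part of what the source reports. "The series", "measured", "known", "first", "only" and "open" are said of these compounds alone.

Measured so far:
compound 1, `COc1cccc(CNCCCNc2ccnc3cc(CCC(C)C)ccc23)c1O`: 5390 nM
compound 2, `COc1cccc(CNCCCNc2ccnc3cc(-c4ccccc4)ccc23)c1O`: 3210 nM

In an ADME assay on HepG2 cells (Homo sapiens) for cytotoxicity, read by luminescence, CellTiter-Glo and ATP content, with a stated time of 72 h (on this read-out lower numbers stand for an effect already at smaller amounts and higher numbers for an effect only at larger amounts of compound), compound 2 gives 3210 nM. Compound 1 gives 5390 nM, and the two numbers stand within the scatter of each other. Compound 3, `COc1cccc(CNCCCNc2ccnc3cc(CC4CCCCC4)ccc23)c1O`, differs from compound 2 by cyclohexylmethyl in place of phenyl on an aromatic carbon. For the measured compounds named here, the one measured step that bears on this, a 1.7-fold lower number from compound 1 to compound 2 (0.23 log units; within the scatter), was within the scatter, so no step beyond the scatter is expected here. Compound 3 is therefore estimated at 4500 nM, with a range of 2000 nM to 10000 nM. The expected step is a 1.4-fold higher number from compound 2 to compound 3 (0.15 log units; within the scatter).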

Compound 3, half-maximal effective concentration: 970 nM
Compound 3: the middle estimate sits 4.6-fold (0.67 log units) above what was measured; the whole stated range lies above it.
By their numbers in this assay, from the lowest: compound 3; then compounds 2 and 1 (each within the scatter of the next).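

At this position on the shared core, the substituent does shift the number in this assay: cyclohexylmethyl in place of phenyl gives a 3.3-fold lower number from compound 2 to compound 3 (0.52 log units; beyond the scatter) and so moves beyond the scatter, which the phenyl and isopentyl pair did not do. Cyclohexylmethyl also separates from isopentyl, with a 5.6-fold lower number from compound 1 to compound 3 (0.74 log units; beyond the scatter) as the larger step. Nothing at hand accounts for either step.

Cyclohexyl and benzyl at this position remain open, so the step cannot yet be assigned to the non-aromatic ring or to its carbon link. Also open, going by these compounds, is how an amine or a carboxylic acid on that ring would read.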